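Ring size at the amine of the shared core

The source may report more compounds than this note shows. Statements on the series, on what has been measured and on what is new or still open speak of the compounds shown alone.

Compound 3 `COc1cc2ncnc(N3CCc4ccccc43)c2cc1NC(=O)/C=C/CN1CCCC1` is one of three measured compounds. In a functional assay on PC-3 cells (Homo sapiens) for antiproliferative activity, read by MTT assay, with a stated time of 72 h (a lower number here means a stronger inhibitor, a higher number a weaker inhibitor), compound 3 gives 2620 nM; compound 1 `C/C=C/C(=O)Nc1cc2c(N3CCCc4ccccc43)ncnc2cc1OC` gives 7520 nM and compound 2 `CCC/C=C/C(=O)Nc1cc2c(N3CCCc4ccccc43)ncnc2cc1OC` gives 2240 nM, so compound 3 sits second highest, close to compound 2 and clearly apart from compound 1. Within the data shown here, the only measured step, a 3.4-fold lower number from compound 1 to compound 2 (0.53 log units; beyond the scatter), concerns the chain on the amide and not the amine ring. Compound 4 `COc1cc2ncnc(N3CCCc4ccccc43)c2cc1NC(=O)/C=C/CN1CCCC1` differs from compound 3 by 1,2,3,4-tetrahydroquinolin-1-yl in place of 2,3-dihydro-1H-indol-1-yl on an aromatic carbon. Among the measured compounds shown here, compounds 1 and 2 already carry this ring, so no step shows its effect. The estimated step of a 1.3-fold lower number from compound 3 to compound 4 (0.12 log units; within the scatter) is therefore expected to stay within the scatter. Compound 4 is estimated at 2000 nM, within 700 nM to 6000 nM.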

Compound 4, half-maximal inhibitory concentration: 1740 nM
The estimate for compound 4 lay 1.1-fold (0.06 log units) above the measured number; measured number inside the range.
By their numbers in this assay, from the lowest: compounds 4, 2 and 3 (each within the scatter of the next); then compound 1.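

In this assay, 1,2,3,4-tetrahydroquinolin-1-yl in place of 2,3-dihydro-1H-indol-1-yl gives a 1.5-fold lower number from compound 3 to compound 4 (0.18 log units; within the scatter), so this direct comparison cannot tell the two rings apart. Among these compounds, on the chain, pyrrolidin-1-yl in place of ethyl gives a 1.3-fold lower number from compound 2 to compound 4 (0.11 log units; within the scatter), also inside the scatter, while pyrrolidin-1-yl in place of hydrogen gives a 4.3-fold lower number from compound 1 to compound 4 (0.64 log units; beyond the scatter), the only one of these steps beyond it. Nothing available explains these numbers. Still open, on these data alone, is how a seven-membered ring in place of 1,2,3,4-tetrahydroquinolin-1-yl would read, and how morpholin-4-yl or dimethylamino would compare with pyrrolidin-1-yl on the chain.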